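Swapping chloro for trifluoromethyl on a urea tail

The source may hold more compounds than are shown below. What is called first, only, known or untested is meant among the compounds shown, and "the series" means these compounds.

Two compounds share a core in which a pyrazole bears a pyridyl group and a chlorinated, hydroxylated phenyl ring, while an aryl tail hangs off the other side. Compound 1 `O=C(Nc1cccc(-n2cc(-c3ccncc3)c(-c3ccc(Cl)c(O)c3)n2)c1)Nc1ccc(Cl)c(Cl)c1` carries that tail through a urea linkage; compound 2 `COc1cc(-c2nn(-c3cccc(NC(=O)c4ccccc4)c3)cc2-c2ccncc2)ccc1Cl` carries a different tail through an amide linkage. For the measured compounds named here, in a functional assay on NCI-H23 cells (Homo sapiens) for inhibition, read by sulforhodamine B assay, with a stated time of 48 h (on this read-out higher numbers stand for weaker inhibition of growth and lower numbers for stronger inhibition of growth), compound 1 gives 29100 nM, the only full number in this small set. Compound 2 gives only a limit of the assay, > 100000 nM, which is the limit of > 100000 nM in this assay, at which 1 of the 2 values shown sits. Going by the values given here, compound 1 therefore stands as the sole compound with a measured concentration here, and no pair of measured compounds differs in a single place.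

Compound 3 `O=C(Nc1cccc(-n2cc(-c3ccncc3)c(-c3ccc(Cl)c(O)c3)n2)c1)Nc1ccc(Cl)c(C(F)(F)F)c1` keeps the urea-linked tail of compound 1 and changes one group on it: trifluoromethyl in place of chloro on an aromatic carbon. No measured step of this kind exists among the shown compounds, so the expectation rests on compound 1 alone. The step of a 1.3-fold lower number from compound 1 to compound 3 (0.12 log units; within the scatter) is expected to stay within the usual scatter, with at most a slight move toward stronger inhibition. Compound 3 is thus estimated at 22000 nM, somewhere between 8000 nM and 60000 nM.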

Compound 3, concentration for total growth inhibition: 3330 nM
Beside the measured number, compound 3's estimate is 6.6-fold (0.82 log units) above it, and the stated range ends above it.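

In this assay, for the compounds shown here, the first measured step of this set shows that the aryl end of the urea tail matters: changing one group, on the aromatic carbon ortho to a chloro group, gives an 8.7-fold lower number from compound 1 to compound 3 (0.94 log units; beyond the scatter) and so moves the compounds beyond the usual scatter of repeated measurements. Turning 3,4-dichlorophenyl into 4-chloro-3-(trifluoromethyl)phenyl adds no ring, no hydrogen-bond donor or acceptor and no net charge. All of these counts stay untouched across this clear gain in growth inhibition. Nothing measured here bears on why this swap strengthens growth inhibition.

Whether the gain is specific to trifluoromethyl stays open, as the compounds shown do not tell how a nitrile, a methyl or a methoxy group on the same aromatic carbon would compare. Also open, on these data alone, is whether the same swap would give a similar step on a tail joined through an amide rather than a urea, or with a different group in place of the remaining chloro.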